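The compounds below may be only part of what the source reports. "The series", "measured", "known", "first", "only" and "open" are said of these compounds alone.

Of the compounds shown here, two built on one shared core have been measured in an ADME assay for solubility; a higher number here means a more soluble compound, a lower number a less soluble compound. Compound 1 `CCNC(=O)CCCNC(=O)[C@H](CC(C)C)NC(=O)OC(C)(C)C` gives 720 ug/mL, and compound 2 `CCNC(=O)CCCNC(=O)[C@H](CC(C)C)NC(=O)N(C)C` gives 770 ug/mL. These two numbers lie within the scatter of each other, so compound 2 stands level with compound 1 and the pair cannot be ranked. The next compound, compound 3 `CCNC(=O)CCCNC(=O)[C@H](CC(C)C)NC(=O)N1CCOCC1`, keeps the core and carries morpholin-4-yl in place of dimethylamino on a carbonyl carbon. For the measured compounds named here, only one measured step bears on this change. Dimethylamino in place of tert-butoxy on a carbonyl carbon gave a 1.1-fold higher number from compound 1 to compound 2 (0.03 log units; within the scatter), a step within the scatter. That is thin evidence, since neither measured compound carries a ring in this place and a single step cannot establish a trend. On this basis, no step beyond the scatter is expected in this assay, and no direction can be favoured. The estimated value for compound 3 is 750 ug/mL, with an expected range of 420 ug/mL to 1200 ug/mL. The expected change is a 1.0-fold lower number from compound 2 to compound 3 (0.01 log units; within the scatter), which would leave it within the scatter.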

Compound 3, solubility: 630 ug/mL
Compound 3: the middle estimate sits 1.2-fold (0.08 log units) above what was measured; low and high end bracket the measured number.
By their numbers in this assay, from the lowest: compounds 3, 1 and 2 (each within the scatter of the next).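

In this assay, for the compounds shown here, this place on a carbonyl carbon has now carried a ring for the first time: morpholin-4-yl, with its one six-membered non-aromatic ring and one hydrogen-bond acceptor, gives a 1.2-fold lower number from compound 2 to compound 3 (0.09 log units; within the scatter) and, set against tert-butoxy, a 1.1-fold lower number from compound 1 to compound 3 (0.06 log units; within the scatter) in this series. Tert-butoxy, dimethylamino and morpholin-4-yl therefore cannot be ranked at this place, and the three compounds show that a ring here can stand in this position without a step beyond the scatter. No measurement is at hand that speaks to why these numbers stay together.

On these data alone, whether an amine, a carboxylic acid or a longer chain on this carbonyl carbon would give a step beyond the scatter remains open, as all three groups compared so far carry no net charge. The shared core is also the same in all three compounds, so these results say nothing about what a change anywhere else in it would do in this assay.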